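Fluoro for chloro on the pendant phenyl of compound 3

The source may hold more compounds than are shown below. What is called first, only, known or untested is meant among the compounds shown, and "the series" means these compounds.

Three compounds of the shared core have numbers in a functional assay on CHO cells for agonist activity at Free fatty acid receptor 1 (Homo sapiens), read by FLIPR and calcium flux, tested at 100 nM; a higher number here means a stronger effect of the compound at the concentration tested, a lower number a weaker effect. Compound 1 `Cc1cccc(-c2nc(C)c(COc3ccc4c(c3)OCC4CC(=O)O)s2)c1` gives 47.2% in this assay, compound 2 `Cc1nc(-c2ccccc2Cl)sc1COc1ccc2c(c1)OCC2CC(=O)O` gives 12.4%, and compound 3 `Cc1nc(-c2ccc(Cl)cc2)sc1COc1ccc2c(c1)OCC2CC(=O)O` gives 53.4%. Compound 3 thus holds the highest of the three numbers, though its gap to compound 1 lies within the scatter, while its gap to compound 2 is large: a number 41 percentage points higher from compound 2 to compound 3 (beyond the scatter). The other step into compound 3, a number 6.2 percentage points higher from compound 1 to compound 3 (within the scatter), is within the scatter.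

Compound 4 `Cc1nc(-c2ccc(F)cc2)sc1COc1ccc2c(c1)OCC2CC(=O)O` differs from compound 3 in one place: fluoro in place of chloro on an aromatic carbon. Going by the values given here, no measured step swaps one halogen for another at the same place on this ring; the two steps that bear on it both change the group on the phenyl. a number 6.2 percentage points higher from compound 1 to compound 3 (within the scatter) shows that exchanging a methyl for a chloro on this ring left the number within the scatter, whereas a number 41 percentage points higher from compound 2 to compound 3 (beyond the scatter) shows that moving the chloro to a different position changed it greatly. Since compound 4 keeps the halogen where compound 3 has it, the expectation is a step of a number 7.4 percentage points lower from compound 3 to compound 4 (within the scatter), that is, none beyond the scatter. Compound 4 is therefore estimated at 46%, with a range from 26% to 64%.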

Compound 4, a percentage reported as activity, at one concentration (the size of the read-out at that concentration, not a potency): 61.6%
Compound 4: middle estimate off by 15.6 percentage points, on the low side, within the range that was stated.
By their numbers in this assay, from the lowest: compound 2; then compounds 1, 3 and 4 (each within the scatter of the next, the first and the last beyond it).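

The halogen exchange at this place can now be read directly: a number 8.2 percentage points higher from compound 3 to compound 4 (within the scatter) in this assay, so 4-chlorophenyl and 4-fluorophenyl cannot be told apart here. Only the 4-fluorophenyl group opens a gap to the 3-methylphenyl group, with a number 14.4 percentage points higher from compound 1 to compound 4 (beyond the scatter) set against a number 6.2 percentage points higher from compound 1 to compound 3 (within the scatter) for the 4-chlorophenyl group, yet this contrast rests on single readings at one concentration and on two compounds that themselves lie within the scatter of each other. The 2-chlorophenyl group stays well apart from both halogens at this place, with a number 49.2 percentage points higher from compound 2 to compound 4 (beyond the scatter) adding to the large step already seen into compound 3, so among these compounds the halogen's place on the phenyl weighs far more than which of the two halogens is present.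

Why these steps take the sizes they do stays open, as nothing measured here bears on a cause. Also open, from the compounds shown here alone, is how a bromo, methoxy, nitrile or trifluoromethyl group at this place would read against compound 3 and compound 4 in this assay, and whether any of them would stand apart from both.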